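Chloro to methyl on the arylamino ring: compound 3 to compound 4

The source may report more compounds than this note shows. Statements on the series, on what has been measured and on what is new or still open speak of the compounds shown alone.

Compound 1 `FC(F)(F)c1ccc(CSc2nc(Nc3ccccc3)c3ccccc3n2)cc1`: 26400 nM
Compound 2 `FC(F)(F)c1ccc(CSc2nc(Nc3ccccc3C(F)(F)F)c3ccccc3n2)cc1`: > 50000 nM
Compound 3 `FC(F)(F)c1ccc(CSc2nc(Nc3ccc(Cl)cc3)c3ccccc3n2)cc1`: 14100 nM

In a functional assay on HGC-27 cells (Homo sapiens) for cytotoxicity, read by MTT assay, with a stated time of 72 h (on this read-out higher numbers stand for weaker inhibition and lower numbers for stronger inhibition), compound 3 gives 14100 nM, the lower of the two numbers reported, but the step of a 1.9-fold lower number from compound 1 to compound 3 (0.27 log units; within the scatter) lies within the scatter, so compound 3 and compound 1 are not separated. The value of compound 2 is a limit of the assay, not a number (the limit of > 50000 nM in this assay, at which 1 of the 3 values shown sits). The step of an at least 3.5-fold lower number from compound 2 to compound 3 (0.54 log units; beyond the scatter) is the only one beyond the scatter, and it exchanges the whole substituted phenyl on the nitrogen.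

Compound 4 `Cc1ccc(Nc2nc(SCc3ccc(C(F)(F)F)cc3)nc3ccccc23)cc1` differs from compound 3 by methyl in place of chloro on an aromatic carbon. Among the measured compounds shown here, no measured step exchanges chloro for methyl; the steps that bear on this position are a 1.9-fold lower number from compound 1 to compound 3 (0.27 log units; within the scatter) and, less directly, an at least 1.8-fold higher number from compound 1 to compound 2 (0.27 log units; that floor lies within the scatter), both small. A single-atom swap on the same aromatic carbon is therefore expected to move the number little, if at all beyond the scatter, in either direction. Compound 4 is expected to give 18000 nM, within 7000 nM to 45000 nM, which means an expected step of a 1.3-fold higher number from compound 3 to compound 4 (0.11 log units; within the scatter).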

Compound 4, half-maximal inhibitory concentration: 34600 nM
Estimate against measurement, compound 4: 1.9-fold (0.28 log units) below; measured number inside the range.
By their numbers in this assay, from the lowest: compounds 3, 1 and 4 (each within the scatter of the next, the first and the last beyond it). At a limit, above all of these: compound 2.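

In this assay, among the compounds shown here, methyl in place of chloro on this aromatic carbon, para to a large group, gives the first exchange of one group for another here that passes the scatter: a 2.5-fold higher number from compound 3 to compound 4 (0.39 log units; beyond the scatter). Neither group is separated from hydrogen, as a 1.9-fold lower number from compound 1 to compound 3 (0.27 log units; within the scatter) and a 1.3-fold higher number from compound 1 to compound 4 (0.12 log units; within the scatter) both lie within the scatter, so chloro and methyl are separated only from each other. The step of an at least 1.4-fold lower number from compound 2 to compound 4 (0.15 log units; that floor lies within the scatter) starts from a limit of the assay, not a number, and gives no order: the limit of > 50000 nM in this assay, at which 1 of the 4 values shown sits.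

On these data alone, how an amine, a methoxy group or a carboxylic acid on the same carbon would compare with chloro and methyl stays open. Also open, as far as these compounds go, are the cause of the step and whether it holds when the rest of the molecule changes.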